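Adding a dimethylamino group to a potent core

The compounds below may be only part of what the source reports. "The series", "measured", "known", "first", "only" and "open" are said of these compounds alone.

Compound 1 `FC(F)(F)c1ccc(Nc2ncnc3sc(Nc4c(Cl)cccc4Cl)nc23)cc1` is a strong inhibitor: in a functional assay on HEK293 cells for antagonist activity at transient receptor potential cation channel subfamily V member 1 (Rattus norvegicus), read by calcium flux (a lower number here means a stronger inhibitor, a higher number a weaker inhibitor), compound 1 gives 3 nM. Its near twin compound 2 `CS(=O)(=O)c1ccc(Nc2ncnc3sc(Nc4c(Cl)cccc4Cl)nc23)cc1` gives 3 nM, and the step of no change at the digits printed from compound 1 to compound 2 (within the scatter) shows that swapping one tail group for another left potency unchanged. Compound 3 `CN(C)c1nc(Nc2ccc(C(F)(F)F)cc2)c2nc(Nc3c(Cl)cccc3Cl)sc2n1` differs from compound 1 elsewhere: dimethylamino in place of hydrogen on an aromatic carbon. Within the data shown here, no measured step touches this position, so the expectation rests on compound 1 alone, with a wide allowance; a small loss is expected, a 2.0-fold higher number from compound 1 to compound 3 (0.30 log units; within the scatter). Compound 3 is therefore estimated at 6 nM, ranging from 1.5 nM to 30 nM.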

Compound 3, half-maximal inhibitory concentration: 43 nM
Beside the measured number, compound 3's estimate is 7.2-fold (0.86 log units) below it; measured number outside the range, above it.
By their numbers in this assay, from the lowest: compounds 1 and 2 (each within the scatter of the next); then compound 3.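

In this assay, the aromatic carbon between two ring nitrogen atoms proves far less forgiving than the tail group: dimethylamino in place of hydrogen gives a 14-fold higher number from compound 1 to compound 3 (1.16 log units; beyond the scatter) and so costs clear potency. The earlier pair changed only the tail, so it said nothing about this carbon. Nothing available explains the loss. On these data alone, whether a methyl or a plain amine on this carbon would keep the potency of compound 1 remains open, and so does whether a larger amine such as morpholine would lose more.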